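A few compounds are considered here, and "the series" means these few. Any claim that something is new, unique, unknown or untested is made for them only; others in the source may bear on it.

Measured compounds:
- compound 1 `CNC(=O)c1cccnc1NCCCN1CCN(c2ccccc2OC)CC1` gives 3.16 nM in a functional assay on aorta for antagonist activity at Alpha-1D adrenergic receptor (Rattus norvegicus); a higher number here means weaker binding, a lower number tighter binding
- compound 2 `COc1ccccc1N1CCN(CCCOc2ccccc2C(=O)N(C)C)CC1` gives 31.6 nM in this assay
- compound 3 `CN(C)C(=O)c1cccnc1NCCCN1CCN(c2ccccc2C#N)CC1` gives 10 nM in this assay

Among these three numbers compound 3 stands second highest: compound 2 sits a step above it and compound 1 a step below it, both gaps beyond the usual scatter. Compound 4 `CN(C)C(=O)c1cccnc1NCCCN1CCN(c2ccccc2OC(F)(F)F)CC1` has not yet been measured in this assay. It differs from compound 3 in one place, (trifluoromethoxy in place of cyano on an aromatic carbon), trifluoromethoxy in place of cyano on an aromatic carbon. Going by the values given here, no measured pair in this set isolates such a change, so the direction has to be guessed; the expected step from compound 3 to compound 4 is small, a 1.3-fold lower number from compound 3 to compound 4 (0.10 log units; within the scatter), not clearly beyond the scatter. Compound 4 is therefore expected to give about 8 nM in this assay, within a range of 2.5 nM to 25 nM.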

Compound 4, dissociation constant: 100 nM
Beside the measured number, compound 4's estimate is 13-fold (1.10 log units) below it, outside the stated range (above it).
By their numbers in this assay, from the lowest: compound 1; then compound 3; then compound 2; then compound 4.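

Trifluoromethoxy in place of cyano on an aromatic carbon, ortho to a large group, gives a 10-fold higher number from compound 3 to compound 4 (1.00 log units; beyond the scatter) in this assay. Going by these compounds alone, this is the first pair in the set that differs in one place, and it shows that the value in this assay depends on which of these two groups the position carries. Nothing in the data shown accounts for the step. Going by these compounds, what a methyl group or a chlorine atom at this position would give remains open, as does whether the same exchange would produce a similar step with the amide of compound 1.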